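A few compounds are considered here, and "the series" means these few. Any claim that something is new, unique, unknown or untested is made for them only; others in the source may bear on it.

Compound 1 `Nc1ncnc2c1c(-c1cnc3[nH]ccc3c1)nn2CCCCCCCCC(=O)NO` and compound 2 `Nc1ncnc2c1c(-c1cnc3[nH]ccc3c1)nn2CCCCC(=O)NO` share one core and differ only in the chain that carries the hydroxycarbamoyl group; the change is hydroxycarbamoyl in place of 4-(hydroxycarbamoyl)butyl on a saturated chain carbon, four bonds along the chain from an aromatic nitrogen. In a functional assay on MDA-MB-231 cells (Homo sapiens) for inhibition, read by MTT assay, with a stated time of 72 h (on this read-out higher numbers stand for weaker inhibition and lower numbers for stronger inhibition), compound 1 gives 11000 nM. Compound 2 reaches only the limit of this assay, > 50000 nM, so no number is known for it. The step is an at least 4.5-fold higher number from compound 1 to compound 2 (0.65 log units; beyond the scatter); its size is set by the limit of > 50000 nM in this assay, at which 1 of the 3 values shown sits. Compound 3 `Nc1nc2cc(-c3nn(CCCCCC(=O)NO)c4ncnc(N)c34)ccc2o1` is built on another core; how the two cores differ is not broken down here. In this assay compound 3 gives 19000 nM. Compound 4 `Nc1nc2cc(-c3nn(CC(=O)NO)c4ncnc(N)c34)ccc2o1` has not yet been measured; it stands to compound 3 as compound 2 stands to compound 1: hydroxycarbamoyl in place of 4-(hydroxycarbamoyl)butyl on a saturated chain carbon bound to an aromatic nitrogen. This is the same kind of change, though in compound 1 the group sits four bonds along the chain from an aromatic nitrogen, while in compound 3 it sits bound to an aromatic nitrogen. The step is expected to be a 3.7-fold higher number from compound 3 to compound 4 (0.57 log units; beyond the scatter), a loss at least as large as the earlier one, because an at least 4.5-fold higher number from compound 1 to compound 2 (0.65 log units; beyond the scatter) already ran past the limit. Compound 4 is therefore estimated at 70000 nM, between 25000 nM and 200000 nM, and may itself be reported only as a limit.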

Compound 4, half-maximal inhibitory concentration: 6310 nM
Compound 4: middle estimate off by 11-fold (1.05 log units), on the high side; the whole stated range lies above it.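

The new step, a 3.0-fold lower number from compound 3 to compound 4 (0.48 log units; beyond the scatter), runs in the opposite direction to the earlier one, so in this assay this change does not carry from one core to the other as a fixed shift: the same change on two cores in this assay, an at least 4.5-fold higher number (0.65 log units; beyond the scatter) from compound 1 to compound 2 and a 3.0-fold lower number (0.48 log units; beyond the scatter) from compound 3 to compound 4, at least 13-fold (1.13 log units) apart, beyond the scatter of two such steps

Compound 2 gives > 50000 nM, which is a limit of the assay and not a number: the limit of > 50000 nM in this assay, at which 1 of the 4 values shown sits.

The two pairs show that the same change can lead to opposite results in this series, but they do not show why, and the core cannot be singled out as the reason, since the change sits four bonds along the chain from an aromatic nitrogen in one pair and on a saturated chain carbon bound to an aromatic nitrogen in the other.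

Going by these compounds, it remains open how the number would respond to a longer chain on the core of compound 3. Also open, on these data alone, is whether a carboxylic acid in place of the hydroxycarbamoyl group would follow either of these two courses.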